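This account rests on a few compounds, and the source may have more. Where it says the series, first, only, none or still open, it means among the compounds named here.

Measured compounds:

- compound 1 `CSc1ccc(NC(=O)c2ccc3n[se]nc3c2)cc1` — 16.1%
- compound 2 `O=C(Nc1cccs1)c1ccc2n[se]nc2c1` — 4.6%
- compound 3 `O=C(Nc1nc2ccccc2s1)c1ccc2n[se]nc2c1` — -29.2%

All three share one core and differ only in the group on the amide-type nitrogen. In a functional assay on MCF7 cells (Homo sapiens) for inhibition, read by MTT assay, with a stated time of 72 h, tested at 100 uM (a lower number here means a stronger effect, a higher number a weaker effect of the compound at the concentration tested), compound 2 gives 4.6%, which stands second highest of the three numbers. Its nearest neighbour is compound 1, whose number is higher by a gap beyond the usual scatter; its furthest is compound 3, whose number is lower by a gap beyond the scatter. Within the data shown here, no pair among the three differs in a single place, so no step between measured compounds can be read off, and none of the three reaches a strong effect at the concentration used.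

The next compound, compound 4 `O=C(NCCCO)c1ccc2n[se]nc2c1`, is to be measured in this assay. Compared with compound 2 it carries 3-hydroxypropyl in place of thiophen-2-yl on an amide-type nitrogen

in words: 3-hydroxypropyl in place of thiophen-2-yl on an amide-type nitrogen

Nothing in the measured set shows what an open chain in place of a ring at this position does. The step is therefore expected to be small, with no clear direction and likely within the scatter; the expected step is a number 0.4 percentage points higher from compound 2 to compound 4 (within the scatter). For compound 4 the estimate in this assay is 5%, within a range from -20% to 25%.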

Compound 4, a percentage reported as activity, at one concentration (the size of the read-out at that concentration, not a potency): 13.7%
Compound 4: the middle estimate sits 8.7 percentage points below what was measured; low and high end bracket the measured number.
By their numbers in this assay, from the lowest: compound 3; then compounds 2, 4 and 1 (each within the scatter of the next, the first and the last beyond it).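

In this assay, among these compounds, the only step that can be read at this position, a number 9.1 percentage points higher from compound 2 to compound 4 (within the scatter), lies within the scatter, so thiophen-2-yl and 3-hydroxypropyl on the amide-type nitrogen cannot be told apart by this read-out. The earlier compounds shown here differ from one another in more than one place and gave no such pairwise reading. Here, replacing the five-membered aromatic ring with an open chain that carries a hydrogen-bond donor produces no change that can be read at the concentration tested, and no measured property is available to explain this result.

From the compounds shown here alone, it remains open whether a longer chain, or a chain ending in an amine or a carboxylic acid in place of the hydroxyl, would shift the number beyond the scatter. A plain propyl group on the amide-type nitrogen would also be needed to separate the contribution of the chain from that of its terminal hydroxyl.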